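The source may hold more compounds than are shown below. What is called first, only, known or untested is meant among the compounds shown, and "the series" means these compounds.

Of the compounds shown here, three that share one core have been measured in an assay on isolated protein (strain Sprague-Dawley) for inhibition of Amine oxidase [flavin-containing] B (Rattus norvegicus), read by spectrophotometry, with a stated time of 5 min; on this read-out lower numbers stand for stronger inhibition and higher numbers for weaker inhibition. Compound 1 `CN(C)C(=O)COc1cc(=O)oc2cc(OCc3cccc(Cl)c3)ccc12` gives 501 nM. Compound 2 `O=C(COc1cc(=O)oc2cc(OCc3cccc(Cl)c3)ccc12)N1CCCCC1` gives 38900 nM, and compound 3 `CCNc1cc(=O)oc2cc(OCc3cccc(Cl)c3)ccc12` gives 28.2 nM. Compound 3 stands lowest of the three: the nearest is compound 1, separated by an 18-fold lower number from compound 1 to compound 3 (1.25 log units; beyond the scatter), and the furthest is compound 2, separated by a 1400-fold lower number from compound 2 to compound 3 (3.14 log units; beyond the scatter). Compound 4 `CCOC(=O)c1cc(=O)oc2cc(OCc3cccc(Cl)c3)ccc12` has not yet been measured. It differs from compound 3 in one place: ethoxycarbonyl in place of ethylamino on an aromatic carbon. The two measured steps that bear on this change are the ones leading into compound 3, an 18-fold lower number from compound 1 to compound 3 (1.25 log units; beyond the scatter) and a 1400-fold lower number from compound 2 to compound 3 (3.14 log units; beyond the scatter). Both brought ethylamino in at this aromatic carbon in place of another group, and both lowered the number by a large margin. Leaving ethylamino again, now for ethoxycarbonyl, is therefore expected to raise the number, and the step into compound 4 is estimated at a 28-fold higher number from compound 3 to compound 4 (1.45 log units; beyond the scatter). For compound 4 the expected value in this assay is 800 nM, within a range from 150 nM to 5000 nM.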

Compound 4, half-maximal inhibitory concentration: 417 nM
Compound 4: the middle estimate sits 1.9-fold (0.28 log units) above what was measured; the range from low to high includes it.
By their numbers in this assay, from the lowest: compound 3; then compounds 4 and 1 (each within the scatter of the next); then compound 2.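

In this assay, ethoxycarbonyl on this aromatic carbon opposite the ring oxygen gives up much of what ethylamino achieved (a 15-fold higher number from compound 3 to compound 4 (1.17 log units; beyond the scatter)), so compound 3 keeps the lowest number of the four. The ester nevertheless stands level with the (dimethylcarbamoyl)methoxy group (a 1.2-fold lower number from compound 1 to compound 4 (0.08 log units; within the scatter)) and far ahead of the ((piperidin-1-yl)carbonyl)methoxy group (a 93-fold lower number from compound 2 to compound 4 (1.97 log units; beyond the scatter)), so a carbonyl-bearing group at this position can still give a number close to that of compound 1. No measurement here explains why these groups rank as they do.

Going by these compounds, it remains open whether the advantage of compound 3 rests on the nitrogen attached to the ring or on the ethyl chain. Methylamino, propylamino or a simple ethoxy group at this position would separate those two parts, and a free carboxylic acid would show how much the ethyl part of the ester matters.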